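The source may hold more compounds than are shown below. What is called first, only, known or untested is meant among the compounds shown, and "the series" means these compounds.

Compounds measured so far:

compound 1 `CCCCNc1nc(N)nnc1OCCOC` — 1000 nM
compound 2 `CCCCNc1nc(N)nnc1OCc1ccccn1` — 330 nM

In an assay on isolated protein for agonist activity at Toll-like receptor 8 (Homo sapiens) (a higher number here means that more compound is needed for the effect, a lower number that less compound is needed), compound 1 gives 1000 nM and compound 2 gives 330 nM. Going by the values given here, of these two numbers compound 2 stands lowest; the only measured step is a 3.0-fold lower number from compound 1 to compound 2 (0.48 log units; beyond the scatter), so compound 2 needs less substance than compound 1 for the same effect.

Compound 3 `CCCCNc1nc(N)nnc1OCc1cccnc1` is the next structure. It differs from compound 2 by pyridin-3-yl in place of pyridin-2-yl on a saturated chain carbon bound to an oxygen on an aromatic ring. Among the compounds with values here, no measured step bears directly on this change: the one known step, a 3.0-fold lower number from compound 1 to compound 2 (0.48 log units; beyond the scatter), concerns a different group at the same place, and nothing shows how the two pyridyl rings compare. A step of no more than modest size is therefore expected in this assay, in either direction, and most likely none beyond the scatter. Compound 3 is estimated at 500 nM, within 150 nM to 1500 nM, which would mean a step of a 1.5-fold higher number from compound 2 to compound 3 (0.18 log units; within the scatter).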

Compound 3, half-maximal effective concentration: 590 nM
Beside the measured number, compound 3's estimate is 1.2-fold (0.07 log units) below it; low and high end bracket the measured number.
By their numbers in this assay, from the lowest: compounds 2, 3 and 1 (each within the scatter of the next, the first and the last beyond it).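

In this assay, pyridin-3-yl in place of pyridin-2-yl gives a 1.8-fold higher number from compound 2 to compound 3 (0.25 log units; within the scatter) and so stays within the scatter, which means these two pyridyl rings cannot be told apart at this place, on a saturated chain carbon bound to an oxygen on an aromatic ring. Pyridin-3-yl in place of methoxymethyl gives a 1.7-fold lower number from compound 1 to compound 3 (0.23 log units; within the scatter) and also stays within the scatter, so the clear separation from methoxymethyl holds for pyridin-2-yl but is not shown for pyridin-3-yl, and "a pyridyl ring beats the ether chain" does not hold for both compounds. Nothing measured here explains these numbers.

From the compounds shown here alone, whether a pyridin-4-yl ring or a plain phenyl ring at this place would stand clearly apart from compound 2 remains open. So does the effect of an amine or a longer chain there.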